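The source may report more compounds than this note shows. Statements on the series, on what has been measured and on what is new or still open speak of the compounds shown alone.

Compound 1 `Cc1cc(Sc2ccc(Cl)cc2)c(S(C)(=O)=O)cc1C(=O)N=C(N)N`: 19 nM in a functional assay for inhibition of sodium/hydrogen exchanger (Oryctolagus cuniculus); on this read-out lower numbers stand for stronger inhibition and higher numbers for weaker inhibition.
Compound 2 `Cc1cc(N2CCCC2)c(S(C)(=O)=O)cc1C(=O)N=C(N)N`: 11 nM in this assay.

On these two numbers compound 2 and compound 1 sit within the scatter of each other, the step being a 1.7-fold lower number from compound 1 to compound 2 (0.24 log units; within the scatter). Compound 3 `Cc1cc(-n2cccn2)c(S(C)(=O)=O)cc1C(=O)N=C(N)N` differs from compound 2 by 1H-pyrazol-1-yl in place of pyrrolidin-1-yl on an aromatic carbon. Going by the values given here, the only measured step, a 1.7-fold lower number from compound 1 to compound 2 (0.24 log units; within the scatter), exchanged a different group at this same carbon and stayed within the scatter, so it bears on the present change only loosely. The account therefore expects no step beyond the scatter in this assay, namely a 1.4-fold higher number from compound 2 to compound 3 (0.13 log units; within the scatter). Compound 3 is estimated at 15 nM, within a range of 6 nM to 40 nM.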

Compound 3, half-maximal inhibitory concentration: 25 nM
For compound 3 the middle estimate is 1.7-fold (0.22 log units) below the measured one, and the stated range covers the measured number.
By their numbers in this assay, from the lowest: compounds 2, 1 and 3 (each within the scatter of the next, the first and the last beyond it).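

Going by these compounds alone, on this carbon, ortho to a methylsulfonyl group, 1H-pyrazol-1-yl in place of pyrrolidin-1-yl gives the first step at this position to pass the scatter, though only modestly (a 2.3-fold higher number from compound 2 to compound 3 (0.36 log units; beyond the scatter)). The two groups have the same number of heavy atoms, so a swap of equal size in that count can still register in this assay, whereas 1H-pyrazol-1-yl in place of (4-chlorophenyl)sulfanyl does not (a 1.3-fold higher number from compound 1 to compound 3 (0.12 log units; within the scatter)). Nothing available explains the step. Still open, as far as these compounds go, is how a morpholine or a dimethylamino group would behave on this carbon.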